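Changing the Heteroaryl Group on the Amide Nitrogen

The source may report more compounds than this note shows. Statements on the series, on what has been measured and on what is new or still open speak of the compounds shown alone.

Three measured compounds share one core and differ only in the group carried on an amide-type nitrogen. In a functional assay on CHO cells for agonist activity at Free fatty acid receptor 2 (Homo sapiens), read by cAMP accumulation (a lower number here means a smaller maximal response, a higher number a larger maximal response), compound 1 `CC(C)[C@H](C(=O)NCc1ccccc1)c1ccc(Cl)cc1` gives < 30%, which is a limit of the assay rather than a number (the limit of < 30% in this assay, at which 1 of the 3 values shown sits). Compound 2 `CC(C)[C@H](C(=O)Nc1ccccn1)c1ccc(Cl)cc1` gives 92% in this assay. Compound 3 `CC(C)[C@H](C(=O)Nc1nncs1)c1ccc(Cl)cc1` gives 115% in this assay, the highest of the two numbers shown. The steps of a number at least 62 percentage points higher from compound 1 to compound 2 (beyond the scatter) and a number at least 85 percentage points higher from compound 1 to compound 3 (beyond the scatter) are both large, whereas the step of a number 23 percentage points higher from compound 2 to compound 3 (beyond the scatter) is modest.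

Compound 4 `CC(C)[C@H](C(=O)Nc1ncc[nH]1)c1ccc(Cl)cc1` has not yet been measured. It differs from compound 3 by 1H-imidazol-2-yl in place of 1,3,4-thiadiazol-2-yl on an amide-type nitrogen. Among the compounds with values here, the only measured step between two such small heteroaryl groups on this nitrogen is the modest one from pyridin-2-yl to 1,3,4-thiadiazol-2-yl; no measured step covers the incoming group itself. A modest step or none beyond the scatter is therefore expected, a number 15 percentage points lower from compound 3 to compound 4 (beyond the scatter). Compound 4 is estimated to reach 100% in this assay, with a likely range from 60% to 130%.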

Compound 4, largest response reached (reported as efficacy), in percent of the reference or control that the assay uses: 55%
For compound 4 the middle estimate is 45 percentage points above the measured one, outside the stated range (below it).
By their numbers in this assay, from the lowest: compound 4; then compound 2; then compound 3. At a limit, below all of these: compound 1.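

In this assay, exchanging one five-membered aromatic ring for another on this nitrogen is far from a neutral change: the 1H-imidazol-2-yl group gives a number 60 percentage points lower from compound 3 to compound 4 (beyond the scatter), and against the six-membered pyridin-2-yl group it gives a number 37 percentage points lower from compound 2 to compound 4 (beyond the scatter). The earlier compounds shown here showed that a heteroaryl group in place of benzyl can raise the maximal response, and this result shows that the size of that gain depends on which ring is used, although the change from benzyl still gives a number at least 25 percentage points higher from compound 1 to compound 4 (beyond the scatter). Compound 1 stands at a limit of the assay, not at a number: the limit of < 30% in this assay, at which 1 of the 4 values shown sits.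

The 1H-imidazol-2-yl and 1,3,4-thiadiazol-2-yl groups differ at once in sulfur, hetero atom count, donors and acceptors, and the compounds shown do not tell which of these differences matters. As far as these compounds go, how a 1-methylimidazol-2-yl or a thiazol-2-yl group would behave on this nitrogen remains open.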